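The source may report more compounds than this note shows. Statements on the series, on what has been measured and on what is new or still open speak of the compounds shown alone.

Compound 1 `N#C[C@@]1(NC(=O)[C@@H](CC(=O)N2CCOCC2)CC2CCC(c3ccccc3)CC2)CCN(C2CCCCC2)C1` has, in an assay on isolated protein for inhibition of cathepsin S (Homo sapiens) (on this read-out higher numbers stand for weaker binding and lower numbers for tighter binding), the entry "not determined" (no result reported), so where it stands on this read-out is not known. A smaller relative that shares the core, compound 2 `N#C[C@@]1(NC(=O)[C@@H](CC(=O)N2CCOCC2)CC2CCCCC2)CCNC1`, gives 123 nM in this assay. Compound 3 `CC1CCC(C[C@H](CC(=O)N2CCOCC2)C(=O)N[C@]2(C#N)CCN(C3CCCCC3)C2)CC1` differs from compound 1 by one exchange, (methyl in place of phenyl on a saturated ring carbon), that is, methyl in place of phenyl on a saturated ring carbon. Among the measured compounds shown here, with no measured pair showing this exchange, the size and direction of the step in this assay cannot be read from the data; a step within the usual scatter is as plausible as a modest shift either way. Compound 3 is expected to reach about 60 nM in this assay, with a likely range from 10 nM to 400 nM.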

Compound 3, dissociation constant: 13.8 nM
Estimate against measurement, compound 3: 4.3-fold (0.64 log units) above; the range from low to high includes it.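

No step from compound 1 to compound 3 can be read in this assay, and no evidence at hand explains the result for compound 3. The compounds shown leave open whether 4-phenylcyclohexyl or 4-methylcyclohexyl gives the tighter binding.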